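Fluorinated phenoxy variants on a shared core

A few compounds are considered here, and "the series" means these few. Any claim that something is new, unique, unknown or untested is made for them only; others in the source may bear on it.

Measured so far, in a functional assay with Homo sapiens as the target; on this read-out higher numbers stand for weaker inhibition and lower numbers for stronger inhibition:
Compound 1, `CC(C)[C@H](NC(=O)COc1cccc2ccccc12)C(=O)N[C@@H](CC(=O)O)C(=O)COc1ccccc1C(F)(F)F`, gives 17300 nM.
Compound 2, `CC(C)[C@H](NC(=O)COc1cccc2ccccc12)C(=O)N[C@@H](CC(=O)O)C(=O)COc1cccc(C(F)(F)F)c1`, gives 16600 nM.
Compound 3, `CC(C)[C@H](NC(=O)COc1cccc2ccccc12)C(=O)N[C@@H](CC(=O)O)C(=O)COc1c(F)cc(F)cc1F`, gives 14900 nM.

Compound 1 has the highest of these three numbers, but the gaps to the others are small: the step of a 1.0-fold lower number from compound 1 to compound 2 (0.02 log units; within the scatter) and the step of a 1.2-fold lower number from compound 1 to compound 3 (0.06 log units; within the scatter) both lie within the scatter, as does a 1.1-fold lower number from compound 2 to compound 3 (0.05 log units; within the scatter). On this assay the three compounds therefore cannot be told apart.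

Compound 4, `CC(C)[C@H](NC(=O)COc1cccc2ccccc12)C(=O)N[C@@H](CC(=O)O)C(=O)COc1c(F)c(F)cc(F)c1F`, has not yet been measured. It differs from compound 1 in one place: 2,3,5,6-tetrafluorophenyl in place of 2-(trifluoromethyl)phenyl on an oxygen on a saturated carbon. All three measured steps bear on this change: each exchanges one fluorinated aryl group for another on the same oxygen on a saturated carbon. The step of a 1.2-fold lower number from compound 1 to compound 3 (0.06 log units; within the scatter) likewise brings in a phenyl ring carrying only fluorine and is the closest parallel. None of these steps moved the read-out beyond the scatter, so no step beyond the scatter is expected for compound 4 in this assay, in either direction.

Compound 4 is therefore expected to give about 15500 nM, with a likely range from 7000 nM to 33000 nM, which would mean an estimated step of a 1.1-fold lower number from compound 1 to compound 4 (0.05 log units; within the scatter).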

Compound 4, half-maximal inhibitory concentration: 6250 nM
Compound 4: the middle estimate sits 2.5-fold (0.39 log units) above what was measured; the measured number lies below the stated range.
By their numbers in this assay, from the lowest: compound 4; then compounds 3, 2 and 1 (each within the scatter of the next).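

In this assay, within the data shown here, the aryl group on this oxygen on a saturated carbon turns out to matter after all, with the first steps beyond the scatter: a 2.8-fold lower number from compound 1 to compound 4 (0.44 log units; beyond the scatter) and a 2.7-fold lower number from compound 2 to compound 4 (0.42 log units; beyond the scatter), both modest in size. A phenyl ring carrying only fluorine is not enough to explain this, since compound 3 has such a ring yet stays within the scatter of compounds 1 and 2, while exchanging 2,4,6-trifluorophenyl for 2,3,5,6-tetrafluorophenyl gives a 2.4-fold lower number from compound 3 to compound 4 (0.38 log units; beyond the scatter). So in this small set the read-out depends on which fluorinated ring is present, and nothing available gives a reason for the shift.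

These compounds leave open whether the number of fluorine atoms or their placement on the ring is what counts, since compounds 3 and 4 differ in both. A plain phenyl and a pentafluorophenyl group on the same oxygen would help to settle this by showing whether the read-out keeps moving in the same direction or the result for compound 4 stands alone.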